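This account rests on a few compounds, and the source may have more. Where it says the series, first, only, none or still open, it means among the compounds named here.

Working notes on the series. In an ADME assay on HepG2 cells (Homo sapiens) for cytotoxicity, read by MTT assay, with a stated time of 3 days (on this read-out lower numbers stand for higher toxicity in this test and higher numbers for lower toxicity in this test), compound 1 (`O=c1nc(NO)ccn1[C@@H]1CS[C@H](CO)O1`) gives 1320000 nM. Compound 2 (`[N-]=[N+]=N[C@@H]1C[C@@H](n2ccc(NO)nc2=O)O[C@H]1CO`) gives 1160000 nM, and compound 3 (`Cc1cn([C@@H]2C=C[C@H](CO)O2)c(=O)nc1N`) gives 1400000 nM. These three values lie within the usual scatter of one another, so compound 1 cannot be ranked against either of the other two, and the set shows no order.

Compound 4 (`O=c1nc(NO)c(F)cn1[C@@H]1CS[C@H](CO)O1`) is still unmeasured. It departs from compound 1 in one place: fluoro in place of hydrogen on an aromatic carbon. This is fluoro in place of hydrogen on an aromatic carbon, ortho to a hydroxyamino group.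

Among the compounds with values here, no two measured compounds differ in one place, so the series holds no direct reading of this change, and no measured compound tells how fluoro behaves here. The structures of compound 2 and compound 3 both differ from compound 1 in more than one place, yet their values stay level with it, and that flatness argues against a large step. The expectation in this assay is therefore a small step toward a lower number, perhaps none beyond the scatter, with the downward lean held only as a cautious allowance.

The estimated step is a 1.5-fold lower number from compound 1 to compound 4 (0.17 log units; within the scatter). For compound 4 the estimated value is 900000 nM, with an expected range of 250000 nM to 1600000 nM.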

Compound 4, half-maximal cytotoxic concentration: 855000 nM
For compound 4 the middle estimate is 1.1-fold (0.02 log units) above the measured one, within the range that was stated.
By their numbers in this assay, from the lowest: compounds 4, 2, 1 and 3 (each within the scatter of the next).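

In this assay, the series now has its first direct reading of fluoro in place of hydrogen on an aromatic carbon, ortho to a hydroxyamino group: a 1.5-fold lower number from compound 1 to compound 4 (0.19 log units; within the scatter). On this single pair, the swap at this position cannot be told apart from no effect, so fluoro here does not take the read-out beyond the usual scatter of the test. No measurement in hand bears on the reason for this reading.

From the compounds shown here alone, whether a larger or different group at this same place, such as chloro, bromo or a carboxylic acid, would give a step beyond the scatter remains open. Going by these compounds, it also remains open whether fluoro at the matching place would read the same way on the core of compound 2, as a single pair on the core of compound 1 cannot settle how far this reading carries to other cores.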